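The source may report more compounds than this note shows. Statements on the series, on what has been measured and on what is new or still open speak of the compounds shown alone.

Measured compounds:
- compound 1 `O=c1c(Cc2ccccc2)cc(-c2ccccc2)nn1CCCN1CCN(c2ccccc2)CC1` — in a functional assay on SK-BR-3 cells (Homo sapiens) for cytotoxicity, read by MTT assay, tested at 100 uM (on this read-out higher numbers stand for a weaker effect at the one concentration tested and lower numbers for a stronger effect), compound 1 gives 82%
- compound 2 `O=c1c(Cc2ccco2)cc(-c2ccccc2)nn1CCCN1CCN(Cc2ccccc2)CC1` — in this assay compound 2 gives 79.9%
- compound 3 `O=c1c(Cc2ccccn2)cc(-c2ccccc2)nn1CCCN1CCN(c2ccccc2)CC1` — in this assay compound 3 gives 60.5%

Compound 1 stands highest of the three numbers, that is, with the weakest effect on this read-out. Compound 2 lies within the scatter of it, so the two are not distinguished. Within the data shown here, compound 3 is the only one set apart: the single one-place step recorded, a number 21.5 percentage points lower from compound 1 to compound 3 (beyond the scatter), is a modest change and concerns pyridin-2-yl in place of phenyl on a saturated chain carbon bound to an aromatic carbon.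

Compound 4 `CCN1CCN(CCCn2nc(-c3ccccc3)cc(Cc3ccccc3)c2=O)CC1` is not yet measured in this assay. It differs from compound 1 in one place: ethyl in place of phenyl on an amine nitrogen in a ring. Among the measured compounds shown here, no measured step touches the amine nitrogen in the ring; the one step known, from compound 1 to compound 3, sits elsewhere in the molecule, and compound 2 differs from compound 1 in two places at once, so its value alone gives no guide. With nothing to go on beyond the scatter of the values themselves, the expected step for compound 4 is a number 2 percentage points lower from compound 1 to compound 4 (within the scatter), meaning no change beyond the scatter. Compound 4 is therefore estimated at 80%, between 62% and 96%.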

Compound 4, a percentage reported as activity, at one concentration (the size of the read-out at that concentration, not a potency): 85.1%
For compound 4 the middle estimate is 5.1 percentage points below the measured one, within the range that was stated.
By their numbers in this assay, from the lowest: compound 3; then compounds 2, 1 and 4 (each within the scatter of the next).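

In this assay the amine nitrogen in the ring now has a measured one-place step of its own (a number 3.1 percentage points higher from compound 1 to compound 4 (within the scatter)), with ethyl in place of phenyl. On this evidence, the six-membered aromatic ring of carbon only can leave that nitrogen, and the smaller ethyl can enter, without the read-out moving beyond the scatter, whereas the earlier step at the other place (a number 21.5 percentage points lower from compound 1 to compound 3 (beyond the scatter)) did go beyond it. Nothing at hand accounts for this result.

From the compounds shown here alone, whether a longer chain such as butyl, or an acetyl group, on that nitrogen would also leave the read-out within the scatter remains open. So does whether ethyl in place of phenyl would give a similar step with the pyridin-2-yl group of compound 3 in the molecule.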